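Replacing a fluorophenyl by an ester at the styryl end

A few compounds are considered here, and "the series" means these few. Any claim that something is new, unique, unknown or untested is made for them only; others in the source may bear on it.

Measured compounds:
- compound 1, `COC(=O)/C=C/c1cccc(N(Cc2ccc(/C=C/c3ccccc3F)cc2)C(=O)C2CCCCC2)c1`: 64 nM
- compound 2, `COC(=O)/C=C/c1cccc(N(Cc2ccc(/C=C/c3ccccc3F)cc2)C(=O)NC(C)C)c1`: 431 nM
- compound 3, `COC(=O)/C=C/c1cccc(N(Cc2ccc(/C=C/C(=O)OC(C)(C)C)cc2)C(=O)c2ccccc2)c1`: 236 nM

In an assay on isolated protein with Bile acid receptor (Homo sapiens) as the target (on this read-out higher numbers stand for an effect only at larger amounts of compound and lower numbers for an effect already at smaller amounts), compound 1 gives 64 nM, the lowest of the three numbers. Differing from compound 1 in two places, compound 3 gives 236 nM, and compound 2 gives 431 nM. Going by the values given here, the single measured step, a 6.7-fold higher number from compound 1 to compound 2 (0.83 log units; beyond the scatter), shows how much the amide side of the shared core can move the read-out.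

Compound 4, `COC(=O)/C=C/c1ccc(CN(C(=O)C2CCCCC2)c2cccc(/C=C/C(=O)OC)c2)cc1`, has not yet been measured in this assay. It keeps the cyclohexyl carbonyl of compound 1 and changes only the other arm: methoxycarbonyl in place of 2-fluorophenyl on a double-bonded chain carbon bound to a double-bonded chain carbon. Among the compounds with values here, no measured step covers this position by itself. Within the data shown here, the only hint comes from compound 3, which carries a tert-butyl ester on the same ethenyl chain and, with a benzoyl group in place of the cyclohexyl carbonyl, sits above compound 1; since two groups change at once there, it shows only that the ester-bearing arm can go with a higher number. The step of a 3.4-fold higher number from compound 1 to compound 4 (0.54 log units; beyond the scatter) is therefore expected to be a moderate increase, beyond the scatter but smaller than the gap to compound 2. Compound 4 is estimated at 220 nM, with a range of 80 nM to 650 nM.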

Compound 4, half-maximal effective concentration: > 1000 nM
Compound 4: a limit, no number; the forecaster's own chance of this, stated with the estimate: 5%; middle value at least 4.5-fold (0.65 log units) from the limit.
By their numbers in this assay, from the lowest: compound 1; then compounds 3 and 2 (each within the scatter of the next). At a limit, above all of these: compound 4.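

Going by these compounds alone, the exchange of 2-fluorophenyl for methoxycarbonyl on a double-bonded chain carbon bound to a double-bonded chain carbon is here seen alone for the first time, with the cyclohexyl carbonyl held fixed, and in this assay it gives an at least 15-fold higher number from compound 1 to compound 4 (1.19 log units; beyond the scatter). Within the data shown here, this arm can therefore move the read-out further than the one change measured on the amide side, which gave a 6.7-fold higher number from compound 1 to compound 2 (0.83 log units; beyond the scatter). The true size of the new step remains unknown, since compound 4 has no number and stands only at a limit of the assay: the limit of > 1000 nM in this assay, at which 1 of the 4 values shown sits.

The compounds shown leave open whether the 2-fluorophenyl matters as such or whether an unsubstituted phenyl on the same ethenyl chain would hold the lower number of compound 1. They also leave open whether a carboxylic acid or a tert-butyl ester in place of the methoxycarbonyl, with the cyclohexyl carbonyl kept, would bring the read-out back within the measurable range.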